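The source may report more compounds than this note shows. Statements on the series, on what has been measured and on what is new or still open speak of the compounds shown alone.

Measured in a functional assay on MCF7 cells (Homo sapiens) for antiproliferative activity, read by MTT assay; on this read-out lower numbers stand for stronger inhibition and higher numbers for weaker inhibition:
- compound 1 `CC1(C)CCc2cc(C(=O)/C=C/c3ccc(OCc4cn(-c5ccc(Cl)cc5)nn4)cc3)c(O)cc2O1`: "not active" (no number reported)
- compound 2 `Cc1c(-n2cc(COc3ccc(/C=C/C(=O)c4ccc5c(c4O)CCC(C)(C)O5)cc3)nn2)cccc1[N+](=O)[O-]`: 145000 nM
- compound 3 `COc1ccc(-n2cc(COc3ccc(/C=C/C(=O)c4ccc5c(c4O)CCC(C)(C)O5)cc3)nn2)c([N+](=O)[O-])c1`: 73100 nM

In this assay compound 1 is reported as "not active" (no number reported), with no number attached, so it serves as a qualitative starting point and the size of any step away from it cannot be calculated.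

Compound 4 `CCCCCn1cc(COc2ccc(/C=C/C(=O)c3cc4c(cc3O)OC(C)(C)CC4)cc2)nn1` keeps the core of compound 1 and changes one group: pentyl in place of 4-chlorophenyl on an aromatic nitrogen. The new pentyl sits on the same aromatic nitrogen of the five-membered ring.

Among the compounds with values here, only one measured step bears on this change. The step is a 2.0-fold lower number from compound 2 to compound 3 (0.30 log units; within the scatter), and it also exchanges the group on that nitrogen. However, it swaps one substituted phenyl for another, on a core that differs from the core of compound 1, and it stays within the scatter. Within the data shown here, no measured pair replaces a ring-bearing group with an open chain, so the data give no firm direction for this change.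

The expectation is therefore no large gain, with compound 4 staying weak, in the range of compound 3 at 73100 nM and compound 2 at 145000 nM, or again yielding no number. For compound 4 the estimated value is 70000 nM, with an expected range from 20000 nM to 200000 nM.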

Compound 4, half-maximal inhibitory concentration: "not active" (no number reported)
Compound 4: no number reported; there is nothing to compare the estimate with.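

In this assay, within the data shown here, compound 1 and compound 4 are both reported as not active, without a number, so no step between them can be read. The compounds shown leave open whether any group on that aromatic nitrogen of the core of compound 1 would give a measurable value. No evidence bears on this result.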